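Swapping an ortho-trifluoromethylphenyl for a dichlorophenyl urea

The source may hold more compounds than are shown below. What is called first, only, known or untested is meant among the compounds shown, and "the series" means these compounds.

Measured compounds:
compound 1 `CCN(CC)CCn1cnnc1-c1cc(Oc2ccc(NC(=O)Nc3ccc(Cl)cc3Cl)cc2F)ccn1` gives 3590 nM in a functional assay on HT-29 cells (Homo sapiens) for antiproliferative activity, read by MTT assay, with a stated time of 72 h; a lower number here means a stronger inhibitor, a higher number a weaker inhibitor;
compound 2 `CN(C)CCCn1cnnc1-c1cc(Oc2ccc(NC(=O)Nc3cccc(C(F)(F)F)c3)cc2F)ccn1` gives 980 nM;
compound 3 `CN(C)CCCn1cnnc1-c1cc(Oc2ccc(NC(=O)Nc3ccccc3C(F)(F)F)cc2F)ccn1` gives 3130 nM.

Among these three numbers compound 3 stands second highest. Its nearest neighbour is compound 1, whose number differs from that of compound 3 only within the usual scatter. Among the measured compounds shown here, its furthest neighbour is compound 2: the one measured step, a 3.2-fold higher number from compound 2 to compound 3 (0.50 log units; beyond the scatter), shows that moving the trifluoromethyl group on the urea-attached phenyl ring raised the number beyond the scatter.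

Compound 4 `CN(C)CCCn1cnnc1-c1cc(Oc2ccc(NC(=O)Nc3ccc(Cl)cc3Cl)cc2F)ccn1` has not yet been measured. It differs from compound 3 in one place: 2,4-dichlorophenyl in place of 2-(trifluoromethyl)phenyl on an amide-type nitrogen. For the measured compounds named here, no measured step covers this particular exchange. Going by the values given here, the only partial guide is compound 1, which carries the same 2,4-dichlorophenyl group but a different chain elsewhere, and its value and that of compound 3 lie within the scatter of each other. The step from compound 2 to compound 3 concerns a different exchange and gives no direction here.

The change from compound 3 to compound 4 is therefore expected to be a 1.0-fold lower number from compound 3 to compound 4 (0.02 log units; within the scatter), with no clear direction beyond the scatter. Compound 4 is estimated at 3000 nM, between 1200 nM and 7500 nM.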

Compound 4, half-maximal inhibitory concentration: 680 nM
Compound 4: the middle estimate sits 4.4-fold (0.64 log units) above what was measured; measured number outside the range, below it.
By their numbers in this assay, from the lowest: compounds 4 and 2 (each within the scatter of the next); then compounds 3 and 1 (each within the scatter of the next).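

In this assay, 2,4-dichlorophenyl in place of 2-(trifluoromethyl)phenyl on the amide-type nitrogen gives a 4.6-fold lower number from compound 3 to compound 4 (0.66 log units; beyond the scatter), so the group at this position matters even with the chain held the same. Measured against 3-(trifluoromethyl)phenyl, the same group gives a 1.4-fold lower number from compound 2 to compound 4 (0.16 log units; within the scatter), so these two groups cannot be told apart here, and among the three compounds sharing this chain only 2-(trifluoromethyl)phenyl stands apart. The chain matters too: with 2,4-dichlorophenyl kept, (dimethylamino)methyl in place of diethylamino on the saturated chain carbon gives a 5.3-fold lower number from compound 1 to compound 4 (0.72 log units; beyond the scatter).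

No measurement available here explains why these numbers move. On these data alone, what remains open is how a morpholine at the end of the chain, in place of the dimethylamino group, would behave.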